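Chloro to bromo swap on the anilino ring

The source may report more compounds than this note shows. Statements on the series, on what has been measured and on what is new or still open speak of the compounds shown alone.

Measured in a functional assay on A549 cells (Homo sapiens) for antiproliferative activity, read by WST assay, with a stated time of 48 h; on this read-out higher numbers stand for weaker inhibition and lower numbers for stronger inhibition:
- compound 1, `Clc1cccc(Nc2ncnc3ccc(NCc4ccc5c(c4)OCCCCO5)cc23)c1`: 44.8 ug/mL
- compound 2, `Clc1cccc(Nc2ncnc3ccc(NCc4ccc5c(c4)OCCCO5)cc23)c1`: 31 ug/mL

Two compounds are in hand. Compound 1 carries the 3-chlorophenylamino group on the shared core and the larger dioxepine-type ring on the benzylamine side; compound 2 differs only in the smaller ring at that position. Going by the values given here, the two numbers in this assay differ by less than the usual scatter, so compound 1 and compound 2 cannot be told apart, and no step between them is drawn.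

The next compound, compound 3, `Brc1cccc(Nc2ncnc3ccc(NCc4ccc5c(c4)OCCCCO5)cc23)c1`, keeps everything of compound 1 except one atom: bromo in place of chloro on an aromatic carbon, sitting meta to the large group of the 3-halophenyl ring. Among the compounds with values here, no measured pair in this set shows what such a halogen exchange does, so there is no step to lean on. With nothing in the data pointing either way, the working expectation is no step beyond the scatter from compound 1 to compound 3.

Compound 3 is therefore expected near 40 ug/mL, with a range from 20 ug/mL to 80 ug/mL. That estimate corresponds to an expected step of a 1.1-fold lower number from compound 1 to compound 3 (0.05 log units; within the scatter), which stays within the scatter.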

Compound 3, half-maximal inhibitory concentration: > 100 ug/mL
Compound 3: only a limit was reported; the forecaster's own chance of this, stated with the estimate: 5%; middle value at least 2.5-fold (0.39 log units) from the limit.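

In this assay compound 3 is recorded only as a limit, > 100 ug/mL. Going by these compounds alone, the halogen on the 3-halophenyl ring is therefore a place that matters: bromo in place of chloro on an aromatic carbon exchanges one heavy atom for one, with no change in hydrogen-bond donors, acceptors or net charge, and still gives an at least 2.2-fold higher number from compound 1 to compound 3 (0.34 log units; beyond the scatter), the first step beyond the scatter in this set, as compound 1 and compound 2 could not be told apart. The printed size of that step is a floor and not a measured difference: the limit of > 100 ug/mL in this assay, at which 1 of the 3 values shown sits.

Only chloro and bromo appear at this place, and a single pair cannot show whether the weaker inhibition tracks the halogen as such, leaving fluoro, iodo, a methyl group or an unsubstituted phenyl ring as open comparisons. Also open, going by these compounds, is whether the same exchange has a similar effect with the smaller ring of compound 2 on the benzylamine side, and nothing here tells what lies behind the step.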